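This account rests on a few compounds, and the source may have more. Where it says the series, first, only, none or still open, it means among the compounds named here.

Measured so far in an assay on isolated protein for displacement of a labelled ligand from Gonadotropin-releasing hormone receptor (Homo sapiens), read by scintillation counting; on this read-out higher numbers stand for weaker inhibition and lower numbers for stronger inhibition: compound 1 `CCc1nc(CN2CCN(c3cccc4nc(-c5ccc(C(C)(C)C)cc5)cn34)CC2)c(C)[nH]1` gives > 10000 nM, which is a limit of the assay and not a number. Compound 2 `CCn1cc(CN2CCN(c3cccn4cc(-c5ccc(C(C)(C)C)cc5)nc34)CC2)c(=O)[nH]c1=O` gives 2.3 nM.

Among the measured compounds shown here, compound 2 thus holds the only actual number in this assay; the other result is the limit of > 10000 nM in this assay, at which 1 of the 2 values shown sits.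

Compound 3 `CC(C)(C)c1ccc(-c2cn3cccc(N4CCN(Cc5ccc6nccnc6c5)CC4)c3n2)cc1` differs from compound 2 in one place: a group of 10 heavy atoms (8 carbon, 2 nitrogen; one six-membered aromatic ring of carbon only, one six-membered aromatic ring with 2 hetero atoms) in place of a group of 10 heavy atoms (6 carbon, 2 nitrogen, 2 oxygen; one six-membered aromatic ring with 2 hetero atoms), on a saturated chain carbon bound to an amine nitrogen in a ring. For the measured compounds named here, no step between two measured compounds is available to calibrate this change. The step from compound 2 to compound 3 is expected to weaken binding beyond the usual scatter, a 13-fold higher number from compound 2 to compound 3 (1.12 log units; beyond the scatter). Compound 3 is estimated at 30 nM, with a range from 5 nM to 300 nM.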

Compound 3, half-maximal inhibitory concentration: 47 nM
Compound 3: the middle estimate sits 1.6-fold (0.19 log units) below what was measured; the range from low to high includes it.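

Quinoxalin-6-yl on a saturated chain carbon bound to an amine nitrogen in a ring gives the first reading of a change at this position: a 20-fold higher number from compound 2 to compound 3 (1.31 log units; beyond the scatter). The entering group has no hydrogen-bond donors, yet compound 3 still gives a measured 47 nM, so a donor in this group is not required for a measurable value. Nothing measured here accounts for the size of this step.

The donor count and the ring system change together in this single step, so their shares remain unresolved. Pyridin-3-yl or phenyl on the same carbon would help to separate them.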